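Swapping a Dichlorophenyl for a Cyanophenyl Group

The compounds below may be only part of what the source reports. "The series", "measured", "known", "first", "only" and "open" are said of these compounds alone.

Compound 1 `Nc1nc(O)c2c(n1)n(C1OC(CO)[C@@H](O)[C@H]1O)c(=O)n2Cc1ccc(Cl)c(Cl)c1` gives 55% in a functional assay on the whole organism (B cells) with Mus musculus as the target (a higher number here means a larger maximal response, a lower number a smaller maximal response), the lower of the two numbers measured, while compound 2 `C=CCn1c(=O)n(CCC(CCOCc2ccccc2)CCOCc2ccccc2)c2nc(N)nc(O)c21` reaches 68%, a gap beyond the usual scatter. Compound 3 `N#Cc1cccc(Cn2c(=O)n(C3OC(CO)[C@@H](O)[C@H]3O)c3nc(N)nc(O)c32)c1` differs from compound 1 in one place: 3-cyanophenyl in place of 3,4-dichlorophenyl on a saturated chain carbon bound to an aromatic nitrogen. Among the measured compounds shown here, no measured pair shows this change, so the expectation rests on compound 1 alone and on the span of the two measured values. The step expected here, a number 5 percentage points higher from compound 1 to compound 3 (within the scatter), is a small rise, not clearly beyond the scatter. Compound 3 is estimated at 60%, within a range from 45% to 80%.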

Compound 3, largest response reached (reported as maximal response), in percent of the reference or control that the assay uses: 16%
Estimate against measurement, compound 3: 44 percentage points above; measured number below the stated range.
By their numbers in this assay, from the lowest: compound 3; then compound 1; then compound 2.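

In this assay the group on a saturated chain carbon bound to an aromatic nitrogen proves far from interchangeable: 3-cyanophenyl in place of 3,4-dichlorophenyl gives a number 39 percentage points lower from compound 1 to compound 3 (beyond the scatter) even though both groups hold 8 heavy atoms and one six-membered aromatic ring. Equal size by this count therefore does not preserve the response in this pair. No evidence at hand accounts for the step. On these data alone, whether the drop follows from adding the nitrile or from losing the chlorines stays open. A plain benzyl group or a monochlorobenzyl group could help separate the two.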